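A furan ring in place of a fluorinated phenyl

The compounds below may be only part of what the source reports. "The series", "measured", "known", "first", "only" and "open" are said of these compounds alone.

Of the compounds shown here, three built on one shared core have been tested in a functional assay on A549 cells (Homo sapiens) for cytotoxicity, read by MTT assay; on this read-out lower numbers stand for stronger inhibition and higher numbers for weaker inhibition. Compound 1, `CCOC(=O)C12C(=O)OCC=C1COC2c1ccccc1F`, carries a 2-fluorophenyl group on that core. In this assay compound 1 gives only a limit of the assay, > 1000000 nM, and not a number. Compound 2, `CCOC(=O)C12C(=O)OCC=C1COC2c1ccc(N(C)C)cc1`, gives 89600 nM in this assay. Compound 3, `CCOC(=O)C12C(=O)OCC=C1COC2c1ccc([N+](=O)[O-])cc1`, gives 36800 nM in this assay. Within the data shown here, the one step that can be counted between two measured compounds is a 2.4-fold lower number from compound 2 to compound 3 (0.39 log units; beyond the scatter).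

Compound 4, `CCOC(=O)C12C(=O)OCC=C1COC2c1ccco1`, has not yet been measured. It differs from compound 1 by furan-2-yl in place of 2-fluorophenyl on a saturated ring carbon. Among the measured compounds shown here, no measured step touches this kind of exchange: the step from compound 2 to compound 3 concerns a substituent on a phenyl ring, not the swap of one aromatic ring for another, so it offers no guide to either size or direction. The only anchor is the limit of > 1000000 nM in this assay, at which 1 of the 3 values shown sits, which fixes the starting point at the edge of what the assay can report. The expected outcome for compound 4 is therefore a weak number near that edge, with a real chance that only a limit is returned again. Compound 4 is estimated at 600000 nM, within a range from 150000 nM to 2000000 nM. This estimate means an expected step of an at least 1.6-fold lower number from compound 1 to compound 4 (0.22 log units; that floor lies within the scatter).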

Compound 4, half-maximal inhibitory concentration: > 1000000 nM
Compound 4 ended at the assay's limit; the forecaster's own chance of this, stated with the estimate: 50%; middle value at least 1.6-fold (0.22 log units) from the limit.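

In this assay, among these compounds, compound 1 and compound 4 both return a limit of the assay and not a number, so no step between them can be read: the limit of > 1000000 nM in this assay, at which 2 of the 4 values shown sit.

The compounds shown leave open whether furan-2-yl or 2-fluorophenyl on the shared core gives the weaker inhibition, and how far past the limit either compound lies.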